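The compounds below may be only part of what the source reports. "The series", "measured", "known", "first", "only" and "open" are said of these compounds alone.

Three measured compounds, and one still to be measured, are compared in an in vitro ADME assay on microsomes from liver (Homo sapiens) for pharmacokinetics, read by LC-MS; a higher number here means faster removal of the compound, a lower number slower removal. Compound 1 `Cc1ccc2nc(C)n(-c3ccc(C(=O)NC4CC4)s3)c2c1` gives 10 mL/min/kg in this assay. Compound 3 `Cc1cc(F)c2nc(C)n(-c3ccc(C(=O)NC4CC4)s3)c2c1` differs from compound 1 by fluoro in place of hydrogen on an aromatic carbon, and in this assay compound 3 gives 12 mL/min/kg, so this change made a step of a 1.2-fold higher number from compound 1 to compound 3 (0.08 log units; within the scatter). Compound 2 `Cc1nc2c(Cl)cccc2n1-c1ccc(C(=O)NC2CC2)s1` rests on a different core; how that core differs from the core of compound 1 is not broken down here. In this assay compound 2 gives only a limit of the assay, < 4 mL/min/kg. Compound 4 `Cc1nc2c(Cl)cc(F)cc2n1-c1ccc(C(=O)NC2CC2)s1` has not yet been measured and differs from compound 2 by fluoro in place of hydrogen on an aromatic carbon. Among the measured compounds shown here, this is the same kind of change as the one from compound 1 to compound 3, though the surroundings differ: in compound 3 the fluoro sits ortho to a fused ring and meta to a methyl group, whereas in compound 4 it sits meta to a chloro group and para to a fused ring. The change is expected to make a step of a number no lower from compound 2 to compound 4 (the limit leaves the size open), small like the earlier one, because the limit of < 4 mL/min/kg in this assay, at which 1 of the 3 values shown sits, is where compound 2 already sits. In this assay compound 4 is therefore estimated at 4 mL/min/kg.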

Compound 4, clearance: 5 mL/min/kg
Estimate against measurement, compound 4: 1.3-fold (0.10 log units) below; measured number inside the range.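

Fluoro in place of hydrogen on an aromatic carbon now appears on two cores, and on the second it gives an at least 1.2-fold higher number from compound 2 to compound 4 (0.09 log units; that floor lies within the scatter). Set side by side in this assay, the two steps read: the same change on two cores in this assay, a 1.2-fold higher number (0.08 log units; within the scatter) from compound 1 to compound 3 and an at least 1.2-fold higher number (0.09 log units; that floor lies within the scatter) from compound 2 to compound 4; the limit leaves it open whether they differ. Neither step points to slower removal, but this does not show that the change has the same size on both cores: compound 2 has only a limit of the assay, < 4 mL/min/kg, so the step from it could be larger than its floor.

The compounds shown leave open whether fluoro on another aromatic carbon of these cores would give a similar step in this assay. They also leave open whether a different group on the same carbon, such as a methoxy group, a nitrile or an amine, would move the number further than fluoro does.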